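Moving a Methyl Group on the Amide Phenyl Ring

The source may report more compounds than this note shows. Statements on the series, on what has been measured and on what is new or still open speak of the compounds shown alone.

Of the compounds shown here, three sharing one core have been measured, all differing only in the ring attached to the amide carbonyl. Compound 3 `Cc1ccccc1C(=O)Nc1cccc(-c2oc3cc(-c4ccc(F)cc4)ccc3c(=O)c2O)c1` gives 2280 nM in a functional assay on MCF7 cells (Homo sapiens) for antiproliferative activity, read by CCK-8 assay, with a stated time of 72 h (a lower number here means a stronger inhibitor, a higher number a weaker inhibitor), and is the strongest of the three, since its steps to both others lie beyond the scatter. Compound 2 `O=C(Nc1cccc(-c2oc3cc(-c4ccc(F)cc4)ccc3c(=O)c2O)c1)c1ccc(Cl)cc1` gives 4730 nM in this assay, and compound 1 `O=C(Nc1cccc(-c2oc3cc(-c4ccc(F)cc4)ccc3c(=O)c2O)c1)c1ccccc1F` gives 7570 nM in this assay. The steps toward compound 3 are modest: a 3.3-fold lower number from compound 1 to compound 3 (0.52 log units; beyond the scatter), and a 2.1-fold lower number from compound 2 to compound 3 (0.32 log units; beyond the scatter). Between the other two, a 1.6-fold lower number from compound 1 to compound 2 (0.20 log units; within the scatter).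

Compound 4 `Cc1cccc(C(=O)Nc2cccc(-c3oc4cc(-c5ccc(F)cc5)ccc4c(=O)c3O)c2)c1` has not yet been measured. It differs from compound 3 in a single place: 3-methylphenyl in place of 2-methylphenyl on a carbonyl carbon. Among the measured compounds shown here, none of the measured steps moves a methyl group from one position of this ring to another; the steps that do bear on the ring partner of the carbonyl were all modest or within the scatter. A change of this kind is therefore expected to give at most a modest step in this assay, and the measured compounds give no firm direction, so a slight weakening is taken as the middle case, meaning an expected 1.5-fold higher number from compound 3 to compound 4 (0.19 log units; within the scatter). Compound 4 is estimated to give 3500 nM in this assay, with a range from 1500 nM to 8000 nM.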

Compound 4, half-maximal inhibitory concentration: 7850 nM
Beside the measured number, compound 4's estimate is 2.2-fold (0.35 log units) below it, within the range that was stated.
By their numbers in this assay, from the lowest: compound 3; then compounds 2, 1 and 4 (each within the scatter of the next).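

The place of the methyl group on this ring matters on its own in this assay: moving it gives a 3.4-fold higher number from compound 3 to compound 4 (0.54 log units; beyond the scatter), although the group that leaves and the group that enters have the same atoms and the same counts. The stronger number of compound 3 therefore does not come with a methyl group as such, since the 3-methylphenyl compound sits within the scatter of the other two (a 1.7-fold higher number from compound 2 to compound 4 (0.22 log units; within the scatter); a 1.0-fold higher number from compound 1 to compound 4 (0.02 log units; within the scatter)), and the 2-fluorophenyl of compound 1 shows that a group at that ring position does not guarantee it either. Nothing measured here explains why the two methyl placements differ.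

The compounds shown leave open how 4-methylphenyl or plain unsubstituted phenyl would read on this carbonyl carbon, and so whether 2-methylphenyl stands out or 3-methylphenyl falls short. They also leave open whether a longer chain such as 2-ethylphenyl, or an amine as in 2-aminophenyl, would keep the number of compound 3.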